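Replacing 4-fluorophenyl with pyridin-4-yl: plasma half-life of compound 4

The compounds below may be only part of what the source reports. "The series", "measured", "known", "first", "only" and "open" are said of these compounds alone.

compound 1 `CCCCCNC(=O)n1cc(-c2ccccc2)oc1=O` with > 2 h as a limit
compound 2 `O=C(NCCCCc1ccccc1)n1cc(-c2ccc(F)cc2)oc1=O` with 1.5 h as a number
compound 3 `COc1cccc(-c2cn(C(=O)NCCCCc3ccccc3)c(=O)o2)c1` with > 2 h as a limit

In an ADME assay on a cell-free system (plasma, Mus musculus) for metabolic stability, read by LC-MS, tested at 2 uM (a lower number here means that the compound disappears faster, a higher number that the compound lasts longer), compound 2 gives 1.5 h as the only true number shown. Compound 1 and compound 3 stand at the same ceiling (the limit of > 2 h in this assay, at which 2 of the 3 values shown sit). Compound 4 `O=C(NCCCCc1ccccc1)n1cc(-c2ccncc2)oc1=O` has pyridin-4-yl in place of 4-fluorophenyl on an aromatic carbon. Going by the values given here, the one measured step bearing on this change is an at least 1.3-fold higher number from compound 2 to compound 3 (0.12 log units; that floor lies within the scatter) and it replaces the same group of compound 2. On that single step, no change beyond the scatter is expected in this assay and the estimate is a 1.3-fold lower number from compound 2 to compound 4 (0.10 log units; within the scatter) with no firm direction. For compound 4 the estimated half-life is 1.2 h with an expected range from 0.5 h to 2.5 h as the likely span.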

Compound 4, half-life: 0.5 h
Compound 4: middle estimate off by 2.4-fold (0.38 log units), on the high side; the measured number falls inside the stated range.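

In this assay, the group next to the ring oxygen can clearly shift the half-life: pyridin-4-yl in place of 4-fluorophenyl brings a 3.0-fold lower number from compound 2 to compound 4 (0.48 log units; beyond the scatter), whereas the earlier step at this place stayed within the scatter. Pyridin-4-yl in place of 3-methoxyphenyl brings an at least 4.0-fold lower number from compound 3 to compound 4 (0.60 log units; beyond the scatter). That second step is only a floor, because compound 3 stands at a limit: the limit of > 2 h in this assay, at which 2 of the 4 values shown sit.

The compounds shown leave open whether a pyridin-3-yl group at this place would give the same drop as pyridin-4-yl. Going by these compounds, whether a pyrimidin-5-yl group would go further also remains open.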